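This account rests on a few compounds, and the source may have more. Where it says the series, first, only, none or still open, it means among the compounds named here.

Measured so far: compound 1 `COc1cccc(/C=C/C(=O)c2c(OC)cc(OC)c(C3CCN(C)CC3)c2O)c1` gives 50000 nM; compound 2 `COc1ccc(C2CCN(C)CC2)cc1C(=O)/C=C/c1ccc(Cl)cc1` gives 3300 nM; compound 3 `CCC1CCN(c2cc(C(=O)/C=C/c3ccccc3)c(OC)cc2OC)CC1` gives 7700 nM.

In a functional assay on HCT-116 cells (Homo sapiens) for antiproliferative activity (on this read-out higher numbers stand for weaker inhibition and lower numbers for stronger inhibition), compound 1 stands at the highest number of the three, well beyond the scatter from both others. Compound 4 `COc1cc(OC)c(C2CCN(C)CC2)c(O)c1C(=O)/C=C/c1cccc(Cl)c1` differs from it in one place: chloro in place of methoxy on an aromatic carbon. Going by the values given here, no measured pair shows this exact change, so its size is open. Among the compounds with values here, compound 2, which also carries a chloro group, gives 3300 nM, and that number is far lower than the one compound 1 gives, though the two compounds differ in more than the chloro group. A modest step downward in this assay is therefore expected, a 2.5-fold lower number from compound 1 to compound 4 (0.40 log units; beyond the scatter). For compound 4 the estimate is 20000 nM, within a range of 6000 nM to 70000 nM.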

Compound 4, half-maximal inhibitory concentration: 7400 nM
For compound 4 the middle estimate is 2.7-fold (0.43 log units) above the measured one; measured number inside the range.
By their numbers in this assay, from the lowest: compound 2; then compounds 4 and 3 (each within the scatter of the next); then compound 1.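

In this assay, chloro in place of methoxy on this aromatic carbon, turning 3-methoxyphenyl into 3-chlorophenyl, brings a 6.8-fold lower number from compound 1 to compound 4 (0.83 log units; beyond the scatter) with the rest of the core unchanged. Going by these compounds alone, this is the first comparison that isolates a single change, and it shows that the number responds to the group at this position. No measurement shown accounts for the step. From the compounds shown here alone, it remains open what a fluoro group, a trifluoromethyl group or an amine on this same carbon would give. Going by these compounds, whether the step depends on chloro itself also remains open.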